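The compounds below may be only part of what the source reports. "The series", "measured", "known", "first", "only" and "open" are said of these compounds alone.

In an ADME assay on MT4 cells (Homo sapiens) for cytotoxicity, read by MTT assay (on this read-out higher numbers stand for lower toxicity in this test and lower numbers for higher toxicity in this test), compound 3 `CC(=O)c1ccc(NC(=O)CSc2nncnc2-c2cccc3ccccc23)c(Br)c1` gives 133000 nM and stands in the upper part of this small set. Compound 1 `COC(=O)c1ccc(NC(=O)CSc2nncnc2-c2cccc3ccccc23)c(Br)c1` at 173000 nM lies within the scatter of it, while compound 2 `CC(=O)c1ccc(NC(=O)CSc2nncnc2-c2ccccc2Cl)c(Br)c1` at 34000 nM lies lower, beyond the scatter. Two measured steps lead to compound 3. One puts methyl in place of methoxy on a carbonyl carbon (a 1.3-fold lower number from compound 1 to compound 3 (0.11 log units; within the scatter)), and the other puts naphthalen-1-yl in place of 2-chlorophenyl on an aromatic carbon (a 3.9-fold higher number from compound 2 to compound 3 (0.59 log units; beyond the scatter)). Compound 4 `O=C(CSc1nncnc1-c1cccc2ccccc12)Nc1ccc([N+](=O)[O-])cc1Cl` differs from compound 3 in a different way (2-chloro-4-nitrophenyl in place of 4-acetyl-2-bromophenyl on an amide-type nitrogen), with 2-chloro-4-nitrophenyl in place of 4-acetyl-2-bromophenyl on an amide-type nitrogen. Among the compounds with values here, no measured compound carries 2-chloro-4-nitrophenyl, so neither step predicts this change directly. Within the data shown here, only the step to compound 3 from compound 1 (a 1.3-fold lower number from compound 1 to compound 3 (0.11 log units; within the scatter)) alters the group that now leaves, and it stayed within the scatter. The modest step from compound 2 concerns another part of the structure. On this limited evidence, no step beyond the scatter is expected in this assay here. The expected change is small (a 1.5-fold lower number from compound 3 to compound 4 (0.17 log units; within the scatter)), and its direction is only a tentative estimate. For compound 4 the expected value is 90000 nM (estimated range 25000 nM to 220000 nM).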

Compound 4, half-maximal cytotoxic concentration: 150000 nM
For compound 4 the middle estimate is 1.7-fold (0.22 log units) below the measured one, within the range that was stated.
By their numbers in this assay, from the lowest: compound 2; then compounds 3, 4 and 1 (each within the scatter of the next).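

In this assay, the exchange of the entire 4-acetyl-2-bromophenyl on the amide-type nitrogen for 2-chloro-4-nitrophenyl comes with a 1.1-fold higher number from compound 3 to compound 4 (0.05 log units; within the scatter), so a change of the whole group, with a different halogen and nitro in place of acetyl, stays as small in this test as the earlier edit to the carbonyl substituent alone, a 1.3-fold lower number from compound 1 to compound 3 (0.11 log units; within the scatter). With naphthalen-1-yl held fixed, this position has now shown no step beyond the scatter, and the only such step in the set remains the one at the aromatic carbon, a 3.9-fold higher number from compound 2 to compound 3 (0.59 log units; beyond the scatter). No measurement shown here explains this result.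

The bromine-to-chlorine and acetyl-to-nitro exchanges arrive together in compound 4, so what each does alone stays unresolved, as does whether they offset each other. As far as these compounds go, it also remains open whether an amine or a carboxylic acid on this ring would stay within the scatter in this assay, and whether 2-chloro-4-nitrophenyl would behave the same way alongside 2-chlorophenyl in place of naphthalen-1-yl.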